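Swapping a nitro for pentafluoroethyl on a relaxant series

The compounds below may be only part of what the source reports. "The series", "measured", "known", "first", "only" and "open" are said of these compounds alone.

Measured so far:
compound 1, `C/N=C(/S)C1=CC(C)(C)Oc2ccc([N+](=O)[O-])cc21`, 1.29 nM
compound 2, `C/N=C(/S)C1=CC(C)(C)Oc2ccc(S(=O)(=O)c3ccccc3)cc21`, 19.5 nM

In a functional assay (aorta) with Rattus norvegicus as the target (on this read-out higher numbers stand for an effect only at larger amounts of compound and lower numbers for an effect already at smaller amounts), compound 1 stands at the lower of the two numbers; compound 2 sits at a higher number, and that gap lies beyond the usual scatter. Compound 3, `C/N=C(/S)C1=CC(C)(C)Oc2ccc(C(F)(F)C(F)(F)F)cc21`, has not been measured yet. It differs from compound 1 in one place: 1,1,2,2,2-pentafluoroethyl in place of nitro on an aromatic carbon. Going by the values given here, no measured pair shows the effect of such a change, so the expectation rests only on compound 1. A modest move toward a higher number is expected, a 3.1-fold higher number from compound 1 to compound 3 (0.49 log units; beyond the scatter). The estimated value for compound 3 in this assay is 4 nM, within a range of 1.3 nM to 15 nM.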

Compound 3, half-maximal effective concentration: 11.8 nM
Compound 3: middle estimate off by 3.0-fold (0.47 log units), on the low side; the range from low to high includes it.
By their numbers in this assay, from the lowest: compound 1; then compounds 3 and 2 (each within the scatter of the next).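

Putting 1,1,2,2,2-pentafluoroethyl in place of nitro on this aromatic carbon gives a 9.1-fold higher number from compound 1 to compound 3 (0.96 log units; beyond the scatter) in this assay and thus shows that the assay responds to what sits at this position. The entering group has no hydrogen-bond acceptors, yet compound 3 at 11.8 nM still acts at low concentration, so acceptors on this group are not required for activity in this range. Nothing available explains the size of the step.

On these data alone, it remains open whether a smaller group, such as trifluoromethyl or nitrile, would stay closer to compound 1. An amine at this carbon is also an open case.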